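Replacing phenyl on the carbonyl carbon of compound 3

This account rests on a few compounds, and the source may have more. Where it says the series, first, only, none or still open, it means among the compounds named here.

Measured in a functional assay on KB cells (Homo sapiens) for antiproliferative activity, read by sulforhodamine B assay, with a stated time of 3 days; a lower number here means a stronger inhibitor of growth, a higher number a weaker inhibitor of growth:
Compound 1 `CN1CCC(C(=O)Nc2cccc(Nc3ncc(F)c(Nc4ccc(F)cc4)n3)c2)CC1`: 1700 nM
Compound 2 `CN(C)c1ccc(C(=O)Nc2cccc(Nc3ncc(F)c(Nc4ccc(F)cc4)n3)c2)cc1`: > 10000 nM, a limit
Compound 3 `O=C(Nc1cccc(Nc2ncc(F)c(Nc3ccc(F)cc3)n2)c1)c1ccccc1`: > 10000 nM, a limit

Compound 3 stands at > 10000 nM, which is a limit and not a number. Compound 4 `CN(C)CC(=O)Nc1cccc(Nc2ncc(F)c(Nc3ccc(F)cc3)n2)c1` has (dimethylamino)methyl in place of phenyl on a carbonyl carbon. Among the compounds with values here, two measured steps bear on this change, and both put an aromatic group where compound 1 has 1-methylpiperidin-4-yl: an at least 5.8-fold higher number from compound 1 to compound 3 (0.76 log units; beyond the scatter), and an at least 5.8-fold higher number from compound 1 to compound 2 (0.76 log units; beyond the scatter). Compound 4 also gives up the phenyl, so a modest step to a lower number is expected in this assay, resting on compound 1 at 1700 nM. The estimate for compound 4 is 3000 nM, with an expected range of 800 nM to 10000 nM. This estimate means an expected at least 3.3-fold lower number from compound 3 to compound 4 (0.52 log units; beyond the scatter).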

Compound 4, concentration for 50% growth inhibition: 1260 nM
For compound 4 the middle estimate is 2.4-fold (0.38 log units) above the measured one; the range from low to high includes it.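

In this assay, the ring-free (dimethylamino)methyl group on the carbonyl carbon gives a measured value where both aromatic groups gave only limits, with an at least 7.9-fold lower number from compound 3 to compound 4 (0.89 log units; beyond the scatter) and an at least 7.9-fold lower number from compound 2 to compound 4 (0.89 log units; beyond the scatter). Both sizes are lower bounds set by a limit: the limit of > 10000 nM in this assay, at which 2 of the 4 values shown sit. The two non-aromatic groups cannot be told apart, with a 1.3-fold lower number from compound 1 to compound 4 (0.13 log units; within the scatter), so the ring of compound 1 is not required for a measured value here.

The compounds shown leave open whether the amine nitrogen itself is needed, since no plain alkyl group such as methyl stands at this place. As far as these compounds go, how a longer chain ending in dimethylamino would read also remains open.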